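Removing the fluoro from compound 3: expected effect

The source may report more compounds than this note shows. Statements on the series, on what has been measured and on what is new or still open speak of the compounds shown alone.

Compound 3 `C=CCn1c(=O)/c(=C\c2cc(Br)ccc2F)[nH]c(=O)/c1=C\c1ccccc1OC` is the weakest of the three measured compounds in a functional assay on U-937 cells (Homo sapiens) for cytotoxicity, read by CCK-8 assay, with a stated time of 72 h (a lower number here means a stronger inhibitor, a higher number a weaker inhibitor), where compound 3 gives 4700 nM. Compound 1 `C=CCn1c(=O)/c(=C\c2cccc(F)c2)[nH]c(=O)/c1=C\c1ccccc1OC` gives 2500 nM in this assay, and compound 2 `C=CCn1c(=O)/c(=C\c2ccccc2Cl)[nH]c(=O)/c1=C\c1ccccc1OC` gives 700 nM in this assay. The step of a 6.7-fold higher number from compound 2 to compound 3 (0.83 log units; beyond the scatter) is the only one beyond the scatter that involves compound 3; the step of a 1.9-fold higher number from compound 1 to compound 3 (0.27 log units; within the scatter) stays within it.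

Compound 4 `C=CCn1c(=O)/c(=C\c2cccc(Br)c2)[nH]c(=O)/c1=C\c1ccccc1OC` differs from compound 3 by hydrogen in place of fluoro on an aromatic carbon. Among the compounds with values here, no measured step removes a fluoro on its own. The nearest bearing is the step of a 1.9-fold higher number from compound 1 to compound 3 (0.27 log units; within the scatter), which adds bromo and shifts the fluoro at the same time and amounts to little, and the step of a 3.6-fold lower number from compound 1 to compound 2 (0.55 log units; beyond the scatter), where a halogen in the same part of the ring as the fluoro of compound 3 gave a modestly lower number. Together these suggest that the fluoro of compound 3 contributes little either way, so only a small step in this assay is expected for compound 4, if anything towards a lower number.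

Compound 4 is therefore estimated at 3200 nM in this assay, with a range of 1200 nM to 8500 nM. The step of a 1.5-fold lower number from compound 3 to compound 4 (0.17 log units; within the scatter) is the expected outcome.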

Compound 4, half-maximal inhibitory concentration: 1100 nM
The estimate for compound 4 lay 2.9-fold (0.46 log units) above the measured number; the measured number lies below the stated range.
By their numbers in this assay, from the lowest: compounds 2 and 4 (each within the scatter of the next); then compounds 1 and 3 (each within the scatter of the next).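

In this assay, within the data shown here, the result isolates the fluoro of the 5-bromo-2-fluorophenyl group for the first time: a 4.3-fold lower number from compound 3 to compound 4 (0.63 log units; beyond the scatter) shows that hydrogen in place of fluoro on this aromatic carbon, ortho to a large group and para to a bromo group, is not a neutral change in the presence of the bromo. The 3-bromophenyl group also separates from the 3-fluorophenyl group, with a 2.3-fold lower number from compound 1 to compound 4 (0.36 log units; beyond the scatter), while a 1.6-fold higher number from compound 2 to compound 4 (0.20 log units; within the scatter) means these two aryl groups cannot be told apart in this assay. The compounds shown offer no measurement that accounts for the size of the fluoro step.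

Open, as far as these compounds go, is whether removing the fluoro has a similar effect when the bromo is absent, and how the same ring carbon would respond to an amine or a carboxylic acid in place of the bromo. Also open, from the compounds shown here alone, is whether the order seen in these U-937 cells carries over to other cell lines.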